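The source may report more compounds than this note shows. Statements on the series, on what has been measured and on what is new or still open speak of the compounds shown alone.

Measured so far in an ADME assay on microsomes from liver (Mus musculus) for metabolic stability; a lower number here means that the compound disappears faster, a higher number that the compound lasts longer:
- compound 1 `CC(C)C(Nc1nnc[nH]1)c1ccc(-c2ccc3cccc(F)c3c2)[nH]c1=O`: 2.42 h
- compound 2 `CC(C)C(c1ncc[nH]1)c1ccc(-c2ccc3cccc(F)c3c2)[nH]c1=O`: < 0.0667 h (a limit, not a number)

Compound 2 has no exact half-life, only the limit < 0.0667 h. This is the limit of < 0.0667 h in this assay, at which 1 of the 2 values shown sits.

Compound 3 `CC(C)C(c1noc(=O)[nH]1)c1ccc(-c2ccc3cccc(F)c3c2)[nH]c1=O` keeps the rest of compound 2 and changes only the group on the saturated chain carbon: a group of 6 heavy atoms (2 carbon, 2 nitrogen, 2 oxygen; one five-membered aromatic ring with 3 hetero atoms) in place of a group of 5 heavy atoms (3 carbon, 2 nitrogen; one five-membered aromatic ring with 2 hetero atoms), on a saturated chain carbon bound to an aromatic carbon and a saturated chain carbon.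

Among the compounds with values here, one measured step bears on this, because it changes the group at the same carbon: an at least 36-fold lower number from compound 1 to compound 2 (1.55 log units; beyond the scatter). That step is large and beyond the scatter, so the group here can matter greatly in this assay. However, the group in compound 3 appears in neither compound 1 nor compound 2, so the size of the next step remains uncertain.

Compound 1 reached 2.42 h with a different group at this carbon, so compound 3 is expected to give a higher number than compound 2. Compound 3 may, however, also end at the limit. The expected change is an at least 7.4-fold higher number from compound 2 to compound 3 (0.87 log units; beyond the scatter).

For compound 3 the estimated half-life is 0.5 h, with an expected range of 0.07 h to 2.5 h.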

Compound 3, half-life: > 3 h
Compound 3: only a limit was reported; the forecaster's own chance of this, stated with the estimate: 25%; at least 6.0-fold (0.77 log units) between middle value and limit.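

In this assay, within the data shown here, compound 2 and compound 3 both carry a five-membered aromatic ring on the saturated chain carbon, and changing only that ring gives an at least 44-fold higher number from compound 2 to compound 3 (1.65 log units; beyond the scatter). The collapse seen with 1H-imidazol-2-yl therefore does not extend to every ring placed directly on this carbon, and the amino link of compound 1 is not needed for a compound to last in this assay. Compound 3 has a limit, not a number: the limit of > 3 h in this assay, at which 1 of the 3 values shown sits. Set against the amino-linked triazole, the result is an at least 1.2-fold higher number from compound 1 to compound 3 (0.09 log units; that floor lies within the scatter), so these values do not separate compound 3 from compound 1.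

How far the half-life of compound 3 actually reaches remains unknown, and nothing here says which atoms of the new ring account for the gap to compound 2. A carboxylic acid or a tetrazole ring on the same saturated chain carbon would show whether other groups behave like the ring of compound 3 or like 1H-imidazol-2-yl.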